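Tetrahydropyridine amide and sulfonyl variants: antiproliferative activity

The source may hold more compounds than are shown below. What is called first, only, known or untested is meant among the compounds shown, and "the series" means these compounds.

Measured so far:
- compound 1 `COc1ccc(-c2cn3cc(C4=CCN(C(=O)c5ccccc5C(F)(F)F)CC4)ccc3n2)cc1OC`: 2550 nM
- compound 2 `COc1ccc(-c2cn3cc(C4=CCN(S(=O)(=O)c5ccccc5)CC4)ccc3n2)cc1OC`: 7660 nM

In a functional assay on A549 cells (Homo sapiens) for antiproliferative activity, read by MTT assay, with a stated time of 48 h (a higher number here means a weaker inhibitor, a lower number a stronger inhibitor), compound 1 gives 2550 nM, the lowest of the two numbers seen; the nearest is compound 2, and the step of a 3.0-fold higher number from compound 1 to compound 2 (0.48 log units; beyond the scatter). That single step is the only one bearing on the new compound.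

Compound 3 `COc1ccc(-c2cn3cc(C4=CCN(S(=O)(=O)CCc5ccccc5)CC4)ccc3n2)cc1OC` has not yet been measured in this assay. Its change from compound 1: phenethylsulfonyl in place of (2-(trifluoromethyl)phenyl)carbonyl on an amine nitrogen in a ring. Like compound 2, compound 3 carries a sulfonyl on the ring nitrogen where compound 1 carries the aryl carbonyl, but with the phenethylsulfonyl rather than the phenylsulfonyl. Going by the values given here, the one bearing step, a 3.0-fold higher number from compound 1 to compound 2 (0.48 log units; beyond the scatter), shows a weakening of modest size when the sulfonyl takes the place of the carbonyl, and there is no measured step that says what the two-carbon link between sulfonyl and phenyl does. The expectation is therefore a weakening of similar size, with the step of a 2.5-fold higher number from compound 1 to compound 3 (0.41 log units; beyond the scatter) expected. Compound 3 is estimated to give 6500 nM in this assay, with a range from 2500 nM to 17000 nM.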

Compound 3, half-maximal inhibitory concentration: 7690 nM
Beside the measured number, compound 3's estimate is 1.2-fold (0.07 log units) below it; low and high end bracket the measured number.
By their numbers in this assay, from the lowest: compound 1; then compounds 2 and 3 (each within the scatter of the next).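

In this assay, phenethylsulfonyl in place of (2-(trifluoromethyl)phenyl)carbonyl on the amine nitrogen in the ring gives a 3.0-fold higher number from compound 1 to compound 3 (0.48 log units; beyond the scatter), a modest weakening of the same size as the step to the phenylsulfonyl compound, while phenethyl in place of phenyl on the sulfonyl sulfur gives a 1.0-fold higher number from compound 2 to compound 3 (0.00 log units; within the scatter). At this position, therefore, the two sulfonyl compounds cannot be told apart, and the phenethyl chain makes no readable difference to the number, which was the question the earlier pair could not address. Both sulfonyl compounds stand beyond the scatter from compound 1, but no available evidence accounts for either step.

Still open, as far as these compounds go, is how much of the step from compound 1 belongs to the sulfonyl and how much to the 2-(trifluoromethyl)phenyl group, a question that a plain benzoyl or a phenylacetyl group on the same nitrogen would address. Also open, from the compounds shown here alone, is whether the insensitivity on the sulfonyl sulfur holds for groups of a different kind, such as a methyl, a longer chain ending in phenyl, or a chain ending in an amine or a carboxylic acid.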